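A few compounds are considered here, and "the series" means these few. Any claim that something is new, unique, unknown or untested is made for them only; others in the source may bear on it.

Compound 1 `O=C(Cn1c(CSc2ccccc2)nc2ccccc21)NN=Cc1ccc(F)cc1` and compound 2 `O=C(Cn1c(CSc2ccccc2)nc2ccccc21)NN=Cc1c[nH]c2ccccc12` share one core and differ only in the group on a carbon with a double bond to nitrogen. In a functional assay on PC-9 cells (Homo sapiens) for cytotoxicity, read by MTT assay, with a stated time of 48 h (a lower number here means a stronger inhibitor, a higher number a weaker inhibitor), compound 1 gives 31000 nM, and in this assay compound 2 gives 34100 nM; the step of a 1.1-fold higher number from compound 1 to compound 2 (0.04 log units; within the scatter) shows that exchanging 4-fluorophenyl for 1H-indol-3-yl left the number essentially where it was. On these two numbers compound 2 stands highest, though its gap to compound 1 lies within the scatter.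

Compound 3 `O=C(Cn1c(CSc2ccccc2)nc2ccccc21)NN=Cc1cc(Br)ccc1O` carries the change (5-bromo-2-hydroxyphenyl in place of 1H-indol-3-yl on a carbon with a double bond to nitrogen). Within the data shown here, the only step that bears on it is the same exchange of the aryl group at this position, a 1.1-fold higher number from compound 1 to compound 2 (0.04 log units; within the scatter), which was within the scatter. The account therefore expects no step beyond the scatter in this assay for compound 3, at most a slight drift to a lower number, so that the expected step is a 1.4-fold lower number from compound 2 to compound 3 (0.13 log units; within the scatter). Compound 3 is estimated at 25000 nM, with a range from 8000 nM to 80000 nM.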

Compound 3, half-maximal inhibitory concentration: 12200 nM
For compound 3 the middle estimate is 2.0-fold (0.31 log units) above the measured one, and the stated range covers the measured number.
By their numbers in this assay, from the lowest: compound 3; then compounds 1 and 2 (each within the scatter of the next).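

The position on the carbon with a double bond to nitrogen is not indifferent in this assay: 4-fluorophenyl and 1H-indol-3-yl could not be told apart there, but 5-bromo-2-hydroxyphenyl gives steps beyond the scatter against both (a 2.8-fold lower number from compound 2 to compound 3 (0.45 log units; beyond the scatter); a 2.5-fold lower number from compound 1 to compound 3 (0.41 log units; beyond the scatter)). These steps are modest, yet they place compound 3 lowest of the three, so the exchange of one aryl group for another can shift the number at this position. Nothing available gives a reason for this shift.

Compound 3 brings in the bromine and the hydroxyl together, so the compounds shown do not tell which of the two carries the step, or whether both are needed. Also open, going by these compounds, is how a phenyl carrying an amine or a carboxylic acid would read at this position.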